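This account rests on a few compounds, and the source may have more. Where it says the series, first, only, none or still open, it means among the compounds named here.

Working notes on the series. In a functional assay on LNCaP cells (Homo sapiens) for cytotoxicity (on this read-out lower numbers stand for an effect already at smaller amounts and higher numbers for an effect only at larger amounts of compound), compound 1 `CCC[C@@H](O)C1=C(Br)C(=C(Br)Br)OC1=O` gives 6.7 ug/mL. Among the compounds with values here, compound 3 `CCCCC1=C(Br)C(=C(Br)Br)OC1=O` gives 9.3 ug/mL in this assay, and the only single-point step measured so far, a 1.4-fold higher number from compound 1 to compound 3 (0.14 log units; within the scatter), concerns hydroxy against hydrogen and not the geometry of the exocyclic double bond. Compound 2 `CCC[C@@H](O)C1=C(Br)/C(=C\Br)OC1=O` reaches only a limit in this assay, < 0.1 ug/mL, which is not a number. Its position is therefore given only by the limit of < 0.1 ug/mL in this assay, at which 1 of the 3 values shown sits. Compound 4 `CCC[C@@H](O)C1=C(Br)/C(=C/Br)OC1=O` is the geometric isomer of compound 2: the two compounds have the same atoms and bonds and differ only in configuration as drawn: 1 of 2 stereo elements differ; a double bond is drawn E in compound 2 and Z in compound 4. Within the data shown here, no measured step bears on a change of double-bond geometry, so neither the size nor the direction of the step in this assay can be read from the data, and compound 2 being a limit leaves the starting point itself open. For compound 4 a value of 0.3 ug/mL is expected, within 0.05 ug/mL to 3 ug/mL. The step of an at least 3.0-fold higher number from compound 2 to compound 4 (0.47 log units; beyond the scatter) is accordingly expected to be modest, with wide uncertainty.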

Compound 4, concentration for half-maximal effect: 0.2 ug/mL
Estimate against measurement, compound 4: 1.5-fold (0.18 log units) above, within the range that was stated.
By their numbers in this assay, from the lowest: compound 4; then compounds 1 and 3 (each within the scatter of the next). At a limit, below all of these: compound 2.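

In this assay, within the data shown here, the step of an at least 2.0-fold higher number from compound 2 to compound 4 (0.30 log units; that floor lies within the scatter) is the first reading on the geometry of the exocyclic double bond, a change on which the hydroxy step could say nothing. Compound 2 stands at a limit, so this step gives only a floor and the full size of the gap stays unknown: the limit of < 0.1 ug/mL in this assay, at which 1 of the 4 values shown sits. Whatever separates the two compounds lies in that double bond alone, with the E form at the limit and the Z form at a number: the fact that compounds 2 and 4 differ only in the configuration as drawn

From the compounds shown here alone, whether the same change of geometry would count equally on the chain without the hydroxy remains open. Also open, going by these compounds, is how either isomer would respond if the hydroxy gave way to an amine or the propyl end of the chain to a longer chain.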